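The source may report more compounds than this note shows. Statements on the series, on what has been measured and on what is new or still open speak of the compounds shown alone.

Series notes. Compound 1 `COc1cc(NC(C)CCCNC(=O)Nc2cccc(F)c2)c2ncccc2c1` and compound 2 `COc1cc(NC(C)CCCNC(=O)NNC(=O)Nc2cccc(F)c2)c2ncccc2c1` share a core and differ by ((3-fluorophenyl)carbamoyl)amino in place of 3-fluorophenyl on an amide-type nitrogen. In a functional assay on MIA PaCa-2 cells (Homo sapiens) for inhibition, read by MTT assay, with a stated time of 72 h (a higher number here means a weaker inhibitor, a lower number a stronger inhibitor), compound 1 gives 22000 nM, and compound 2 gives 69000 nM; the step between them is a 3.1-fold higher number from compound 1 to compound 2 (0.50 log units; beyond the scatter). Compound 3 `COc1cc(NC(C)CCCNC(=O)Nc2cccc(C(F)(F)F)c2)c2ncccc2c1` differs from compound 1 by trifluoromethyl in place of fluoro on an aromatic carbon, placed on an aromatic carbon of a six-membered aromatic ring of carbon only, meta to a large group. In this assay compound 3 gives 17000 nM, so the step reads a 1.3-fold lower number from compound 1 to compound 3 (0.11 log units; within the scatter). Compound 2 against compound 3 reads a 4.1-fold lower number from compound 2 to compound 3 (0.61 log units; beyond the scatter). Compound 4 `COc1cc(NC(C)CCCNC(=O)NNC(=O)Nc2cccc(C(F)(F)F)c2)c2ncccc2c1` is not yet measured; it differs from compound 2 by trifluoromethyl in place of fluoro on an aromatic carbon, at a place described in the same words as for compound 1 to compound 3, so the change is the same one on the other core. For compound 4 the expected step is a 1.3-fold lower number from compound 2 to compound 4 (0.10 log units; within the scatter), resting on the measured step of a 1.3-fold lower number from compound 1 to compound 3 (0.11 log units; within the scatter), which stays within the scatter; with a single precedent the expectation is loose. Compound 4 is accordingly estimated at 55000 nM, with an expected range from 25000 nM to 120000 nM.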

Compound 4, half-maximal inhibitory concentration: 5600 nM
The estimate for compound 4 lay 9.8-fold (0.99 log units) above the measured number, and the stated range ends above it.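

In this assay, trifluoromethyl in place of fluoro gives a 12-fold lower number from compound 2 to compound 4 (1.09 log units; beyond the scatter), and this step does not match the one seen for the same change on the core of compound 1: the same change on two cores in this assay, a 1.3-fold lower number (0.11 log units; within the scatter) from compound 1 to compound 3 and a 12-fold lower number (1.09 log units; beyond the scatter) from compound 2 to compound 4, 9.5-fold (0.98 log units) apart, beyond the scatter of two such steps. The size of this change therefore does not carry from one core to the other in this series, and a step read on one core is a poor guide to the step on the other. With a single pair on each core, the data show that the two steps differ but not why, and they do not show how far the larger step extends beyond compound 4.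

Still open, from the compounds shown here alone, is whether the larger step on the core of compound 2 also appears with other groups at the same place on the aromatic ring, such as chloro, methoxy or nitrile. Also open, going by these compounds, is whether it persists with a shorter alkyl chain in place of the present one.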